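A Methyl Added to the Core of Compound 1

This account rests on a few compounds, and the source may have more. Where it says the series, first, only, none or still open, it means among the compounds named here.

For the measured compounds named here, compound 1 `C[C@H](Nc1nc(N)nc(N)c1C#N)c1cc2ccc(F)cn2c(=O)c1-c1ccccc1` is one of two compounds measured in an ADME assay on the whole organism (Mus musculus, strain BALB/C) for pharmacokinetics, read by LC-MS, with a stated time of 24 h, at a dose of 1 mg/kg by the intravenous route; a lower number here means less compound in the circulation, a higher number more compound in the circulation at the dose given. In this assay compound 1 gives 2300 nM, the higher of the two numbers. Compound 2 `C[C@H](Nc1nc(N)nc(N)c1C#N)c1cc(=O)n2cc(F)ccc2c1-c1cc(F)cc(F)c1` gives 1100 nM in this assay, a gap beyond the usual scatter. Compound 3 `Cc1c([C@H](C)Nc2nc(N)nc(N)c2C#N)c(-c2ccccc2)c(=O)n2cc(F)ccc12` differs from compound 1 by methyl in place of hydrogen on an aromatic carbon. Going by the values given here, no measured pair shows the effect of such a change, so the expected step of a 1.2-fold lower number from compound 1 to compound 3 (0.06 log units; within the scatter) is small, not beyond the scatter, in either direction. Compound 3 is therefore expected to reach 2000 nM, within 900 nM to 4500 nM.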

Compound 3, maximal plasma concentration: 1300 nM
Beside the measured number, compound 3's estimate is 1.5-fold (0.19 log units) above it, within the range that was stated.
By their numbers in this assay, from the lowest: compounds 2, 3 and 1 (each within the scatter of the next, the first and the last beyond it).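

In this assay, for the compounds shown here, methyl in place of hydrogen on an aromatic carbon gives a 1.8-fold lower number from compound 1 to compound 3 (0.25 log units; within the scatter) and so, as the first measured pair for this position, shows that this single added carbon leaves the number indistinguishable from that of the hydrogen compound. No measurement at hand offers a reason for this result. As far as these compounds go, whether a longer chain, an amine or a carboxylic acid at the same position would also stay this close remains open. So does whether methyl would behave the same way on compound 2.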